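Fluorine Added to Compound 3: Expecting Little Movement

The source may report more compounds than this note shows. Statements on the series, on what has been measured and on what is new or still open speak of the compounds shown alone.

Of the compounds shown here, three have been measured in a functional assay on CHO cells for agonist activity at Free fatty acid receptor 1 (Homo sapiens), read by FLIPR and calcium flux; on this read-out lower numbers stand for an effect already at smaller amounts and higher numbers for an effect only at larger amounts of compound. Compound 1 `COc1ccccc1-c1cccc(COc2ccc(S(=O)(=O)CC(=O)O)cc2)c1` gives 195 nM in this assay. Compound 3 `Cc1nc(-c2ccccc2)sc1COc1ccc(S(=O)(=O)CC(=O)O)cc1` gives 331 nM in this assay, which is the higher of the two numbers available, though its gap to compound 1 lies within the usual scatter of repeated measurements, so no order between the two can be claimed. Compound 2 `O=C(O)CS(=O)(=O)c1cccc(OCc2ccc(-c3ccccc3)cc2)c1` returns only a limit of this assay, > 1000 nM, and no number is known for it. That reading is the limit of > 1000 nM in this assay, at which 1 of the 3 values shown sits.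

Compound 4 `Cc1nc(-c2cccc(F)c2)sc1COc1ccc(S(=O)(=O)CC(=O)O)cc1` differs from compound 3 in one place: fluoro in place of hydrogen on an aromatic carbon. The fluoro enters on a six-membered aromatic ring of carbon only, meta to a large group; cut one bond further out, the difference reads phenyl to 3-fluorophenyl. Among the measured compounds shown here, no measured pair shows this particular change, so there is no step on which to rest a direction. A single fluorine is a small addition, and the expected movement in this assay is correspondingly small: the step is estimated at a 1.1-fold lower number from compound 3 to compound 4 (0.04 log units; within the scatter), which stays within the scatter. Compound 4 is therefore expected to give 300 nM in this assay, with a likely range from 120 nM to 800 nM.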

Compound 4, half-maximal effective concentration: 275 nM
The estimate for compound 4 lay 1.1-fold (0.04 log units) above the measured number, and the stated range covers the measured number.
By their numbers in this assay, from the lowest: compounds 1, 4 and 3 (each within the scatter of the next). At a limit, above all of these: compound 2.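

The series now holds its first step between two measured compounds that differ in one place: with fluoro in place of hydrogen on an aromatic carbon, meta to a large group, this assay gives a 1.2-fold lower number from compound 3 to compound 4 (0.08 log units; within the scatter). The change from phenyl to 3-fluorophenyl therefore leaves the number indistinguishable from that of the parent, showing that this position on the six-membered aromatic ring can carry a fluoro without a shift that can be told from the scatter. Nothing in the data shown bears on the reason for this outcome.

On these data alone, one fluoro at one position does not settle how far this place tolerates change, so it remains open whether a chloro, a trifluoromethyl or a nitrile at the same carbon, or a fluoro on another carbon of that ring, would move the number beyond the scatter. Also open, as far as these compounds go, is whether fluoro would behave the same way with a different group in the rest of the molecule, such as an ethyl in place of the methyl on the shared core.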